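The source may hold more compounds than are shown below. What is called first, only, known or untested is meant among the compounds shown, and "the series" means these compounds.

Measured so far in a functional assay on HeLa cells (Homo sapiens) for antiproliferative activity, read by MTT assay, with a stated time of 72 h (a lower number here means a stronger inhibitor, a higher number a weaker inhibitor), are two compounds.
- compound 1 `CC(C)=CC(=O)Nc1cccc(Oc2nc(Nc3cccc(C#N)c3)nc3c2CSCC3)c1` gives 29200 nM
- compound 2 `C/C=C/C(=O)Nc1cccc(Oc2nc(Nc3ccc(OC)nc3)nc3c2CSCC3)c1` gives 16500 nM

Compound 2 at 16500 nM stands within the scatter of compound 1, so these two numbers set no order between them.

Compound 3 `COc1ccc(Nc2nc3c(c(Oc4cccc(NC(=O)C=C(C)C)c4)n2)CSCC3)cn1` has not yet been measured. It keeps the structure of compound 2 except on a carbonyl carbon whose other neighbour is an amide-type nitrogen, where 2-methylprop-1-en-1-yl stands in place of prop-1-en-1-yl (2-methylprop-1-en-1-yl in place of prop-1-en-1-yl on a carbonyl carbon). Going by the values given here, no measured pair shows this change alone, so the evidence for it is indirect. Compound 1 already carries 2-methylprop-1-en-1-yl on its carbonyl carbon and gives 29200 nM in this assay without leaving the scatter of compound 2. On that basis, no step beyond the scatter is expected in this assay, and any drift is expected to be slightly towards a higher number. The estimated change is a 1.2-fold higher number from compound 2 to compound 3 (0.08 log units; within the scatter) and is expected to remain small. For compound 3 the expected value is 20000 nM with an estimated range of 8000 nM to 50000 nM.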

Compound 3, half-maximal inhibitory concentration: 29200 nM
For compound 3 the middle estimate is 1.5-fold (0.16 log units) below the measured one; the measured number falls inside the stated range.
By their numbers in this assay, from the lowest: compounds 2, 1 and 3 (each within the scatter of the next).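

The change from prop-1-en-1-yl to 2-methylprop-1-en-1-yl on the carbonyl carbon can now be read directly: in this assay it gives a 1.8-fold higher number from compound 2 to compound 3 (0.25 log units; within the scatter), so the added carbon at this place does not separate the pair. A second direct reading comes from the aromatic-ring nitrogen, where 6-methoxypyridin-3-yl in place of 3-cyanophenyl gives no change at the digits printed from compound 1 to compound 3 (within the scatter), so with 2-methylprop-1-en-1-yl on the carbonyl carbon this exchange also leaves the pair unresolved. No measurement available here offers an explanation for either step.

Both changes therefore stay within the scatter, and these three compounds do not show whether either place can move the number further. Open cases are a saturated propyl chain or a dimethylaminomethyl-bearing alkenyl group on the carbonyl carbon, and a carboxylic acid or an amine on the aromatic ring carried by the nitrogen, each of which would need reading against compound 2 or compound 3 in this assay.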